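The compounds below may be only part of what the source reports. "The series", "measured", "known", "first", "only" and "open" are said of these compounds alone.

In a functional assay on HL-60 cells (Homo sapiens) for cytotoxicity, read by WST assay, with a stated time of 48 h (a lower number here means that less compound is needed, a higher number that more compound is needed for the effect), compound 1 `Clc1ccc(C[C@H]2COC[C@@H]2Cc2ccccc2)cc1Cl` gives 19000 nM. Two close relatives have been measured alongside it. Compound 2 `CCOc1ccccc1C[C@H]1COC[C@@H]1Cc1ccc(Cl)c(Cl)c1`, with ethoxy in place of hydrogen on an aromatic carbon, gives 29000 nM. Compound 3 `Cc1cccc(C[C@H]2COC[C@@H]2Cc2ccc(Cl)c(Cl)c2)c1`, with methyl in place of hydrogen on an aromatic carbon, gives 28000 nM. Compound 1 therefore stands within the usual scatter of both relatives, and the numbers do not set it apart from either.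

Compound 4 `COc1ccc(C[C@H]2COC[C@@H]2Cc2ccc(Cl)c(Cl)c2)cc1` has not yet been measured. Its difference from compound 1 is methoxy in place of hydrogen on an aromatic carbon. Put simply, it has methoxy in place of hydrogen on an aromatic carbon, para to a large group.

Among the measured compounds shown here, two measured steps bear on this change, as each also replaces a hydrogen on an aromatic carbon with a group: a 1.5-fold higher number from compound 1 to compound 2 (0.18 log units; within the scatter) and a 1.5-fold higher number from compound 1 to compound 3 (0.17 log units; within the scatter). Neither step goes beyond the scatter. They do not show what a group does at exactly this place, so the range has to stay fairly wide.

No step beyond the scatter is expected in this assay, and the estimated step is a 1.4-fold higher number from compound 1 to compound 4 (0.15 log units; within the scatter). For compound 4 the estimated value is 27000 nM, with an expected range from 13000 nM to 55000 nM.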

Compound 4, half-maximal effective concentration: 39000 nM
The estimate for compound 4 lay 1.4-fold (0.16 log units) below the measured number, and the stated range covers the measured number.
By their numbers in this assay, from the lowest: compounds 1, 3, 2 and 4 (each within the scatter of the next, the first and the last beyond it).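

In this assay the methoxy group, on an aromatic carbon and para to a large group, gives a 2.1-fold higher number from compound 1 to compound 4 (0.31 log units; beyond the scatter) and so more compound is needed for the effect once it is present. Among the compounds shown here, this is the first step away from compound 1 that passes the usual scatter, which the ethoxy and methyl steps did not do, but it passes only modestly and a single step at a single place supports no general rule. Nothing available explains why the number moves, so this shift stands as an observation without a known cause.

The compounds shown leave open how this same place would respond to other groups, such as a hydroxyl, a fluorine atom, an amine or a longer chain like propoxy, and whether any of them would move the number further or bring it back towards that of compound 1. They also leave open whether methoxy would give a similar step on another carbon of the same ring.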